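A few compounds are considered here, and "the series" means these few. Any claim that something is new, unique, unknown or untested is made for them only; others in the source may bear on it.

In a functional assay on PC-3 cells (Homo sapiens) for inhibition, read by MTT assay, with a stated time of 72 h (a higher number here means a weaker inhibitor, a lower number a stronger inhibitor), compound 2 `S=C(SCc1cn(Cc2ccc(Cl)cc2)nn1)N1CCNCC1` gives only a limit, > 128000 nM. Compound 3 `Fc1ccc(Cn2cc(CSC(=S)N3CCNCC3)nn2)cc1` likewise gives only a limit, > 128000 nM. Compound 1 `S=C(SCc1cn(Cc2ccccc2Cl)nn1)N1CCNCC1` has no value, "not determined" (no result reported). Compound 3 thus stands where compound 2 stands, since both sit at the limit of > 128000 nM in this assay, at which 2 of the 3 values shown sit. For the measured compounds named here, the one step between measured compounds, a step that the two limits leave unreadable from compound 2 to compound 3, cannot be sized, as both of its ends are limits. Compound 4 `Cc1ccc(Cn2cc(CSC(=S)N3CCNCC3)nn2)cc1` differs from compound 3 by methyl in place of fluoro on an aromatic carbon. Going by the values given here, no measured step of readable size bears on this change, and both neighbouring values stop at the limit, so no shift beyond the scatter is expected in this assay. Compound 4 is therefore estimated at 200000 nM, within 50000 nM to 600000 nM, a step that the limit leaves unreadable from compound 3 to compound 4, most likely reported again only as a limit.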

Compound 4, half-maximal inhibitory concentration: 19800 nM
Estimate against measurement, compound 4: 10-fold (1.00 log units) above, outside the stated range (below it).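

At this place on the ring, para to a large group, methyl is the only group shown that gives a true number in this assay; fluoro and chloro do not. Putting methyl in place of fluoro gives an at least 6.4-fold lower number from compound 3 to compound 4 (0.81 log units; beyond the scatter), and putting methyl in place of chloro gives an at least 6.4-fold lower number from compound 2 to compound 4 (0.81 log units; beyond the scatter). Both sizes are minimums, since compound 2 and compound 3 each stop at a limit: the limit of > 128000 nM in this assay, at which 2 of the 4 values shown sit.

From the compounds shown here alone, whether an ethyl group, a methoxy group or an amine at this place would go further remains open. Going by these compounds, the true distance from either halogen compound to compound 4 also remains open.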